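Trimming one carbon from the chain of compound 3

The compounds below may be only part of what the source reports. "The series", "measured", "known", "first", "only" and "open" are said of these compounds alone.

In an assay on isolated protein for inhibition of myosin-2 (Bos taurus), read by spectrophotometry, with a stated time of 24 min (a lower number here means a stronger inhibitor, a higher number a weaker inhibitor), compound 3 `CCCCCC/N=C(\C)c1c(O)c2ccccc2oc1=O` gives 2900 nM and holds the lowest of the two numbers given. Compound 1 `C/C(=N\CC(C)C)c1c(O)c2ccccc2oc1=O` gives 34000 nM in this assay. For compound 2 `C/C(=N\Cc1ccccc1C)c1c(O)c2ccccc2oc1=O` this assay reports only a limit, >= 100000 nM. The step of a 12-fold lower number from compound 1 to compound 3 (1.07 log units; beyond the scatter) is large, as is an at least 34-fold lower number from compound 2 to compound 3 (1.53 log units; beyond the scatter), while an at least 2.9-fold higher number from compound 1 to compound 2 (0.46 log units; beyond the scatter) is at least modest. Compound 4 `CCCCC/N=C(\C)c1c(O)c2ccccc2oc1=O` differs from compound 3 by hydrogen in place of methyl on a saturated chain carbon, five bonds along the chain from a double-bonded nitrogen. For the measured compounds named here, no measured step removes a single carbon from the end of this chain; the steps into compound 3 show only that the pentyl chain gave lower numbers than isopropyl or 2-methylphenyl. The step of a 1.7-fold higher number from compound 3 to compound 4 (0.24 log units; within the scatter) is therefore expected to be small, toward a higher number. Compound 4 is estimated at 5000 nM, between 2000 nM and 15000 nM.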

Compound 4, half-maximal inhibitory concentration: 6700 nM
Beside the measured number, compound 4's estimate is 1.3-fold (0.13 log units) below it; the range from low to high includes it.
By their numbers in this assay, from the lowest: compound 3; then compound 4; then compound 1. At a limit, above all of these: compound 2.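

In this assay hydrogen in place of methyl, five bonds along the chain from a double-bonded nitrogen, gives a 2.3-fold higher number from compound 3 to compound 4 (0.36 log units; beyond the scatter) and so shows that a single carbon at this place already counts. The butyl chain still keeps the lower number against isopropyl and 2-methylphenyl, with a 5.1-fold lower number from compound 1 to compound 4 (0.71 log units; beyond the scatter) and an at least 14-fold lower number from compound 2 to compound 4 (1.17 log units; beyond the scatter) on the shared core. The second of these rests on a limit for compound 2, not a number: the limit of >= 100000 nM in this assay, at which 1 of the 4 values shown sits. Going by these compounds, whether a longer chain would lower the number further stays open, as does the effect of an amine or a carboxylic acid at the chain end.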